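From bromo to iodo on compound 2

This account rests on a few compounds, and the source may have more. Where it says the series, first, only, none or still open, it means among the compounds named here.

Of the compounds shown here, three have been measured so far in a functional assay on DU-145 cells (Homo sapiens) for inhibition, read by trypan blue exclusion, with a stated time of 96 h (a higher number here means a weaker inhibitor of growth, a lower number a stronger inhibitor of growth), on this series. Compound 2 (`O=C(/C(=C/c1ccc(Br)cc1)S(=O)(=O)Cc1ccc(I)cc1)c1ccc(I)cc1`) gives 20000 nM and sits level, within the scatter, with compound 3 (`O=C(O)c1cc(/C=C(/Sc2ccc(Br)cc2)C(=O)c2c(F)c(F)c(F)c(F)c2F)ccc1O`) at 25000 nM on the same read-out. Compound 1 (`COc1ccc(C(=O)/C(=C\c2ccc(OC)c(O)c2)Sc2ccc(F)cc2)cc1`) gives 1000 nM and so lies well beyond the scatter on the stronger side of compound 2.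

Compound 4 (`O=C(/C(=C/c1ccc(I)cc1)S(=O)(=O)Cc1ccc(I)cc1)c1ccc(I)cc1`) has not yet been measured. It carries iodo in place of bromo on an aromatic carbon, para to a large group (iodo in place of bromo on an aromatic carbon), so that a 4-bromophenyl becomes a 4-iodophenyl. For the measured compounds named here, no two measured compounds differ in one place only, so the data offer no direct precedent for this change. The expected step is small, with a 1.1-fold lower number from compound 2 to compound 4 (0.05 log units; within the scatter) as the estimate, and no move beyond the scatter is expected in either direction. For compound 4 the estimated value is 18000 nM with an expected range (6000 nM to 45000 nM).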

Compound 4, concentration for 50% growth inhibition: 50000 nM
The estimate for compound 4 lay 2.8-fold (0.44 log units) below the measured number; measured number above the stated range.
By their numbers in this assay, from the lowest: compound 1; then compounds 2, 3 and 4 (each within the scatter of the next, the first and the last beyond it).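

For the compounds shown here, this is the first comparison that isolates one change. In this assay, iodo in place of bromo on an aromatic carbon, para to a large group, gives a 2.5-fold higher number from compound 2 to compound 4 (0.40 log units; beyond the scatter), so growth inhibition here responds to which of these two halogens is present, though the step is modest. It also shows that the 4-bromophenyl and 4-iodophenyl cannot be treated as interchangeable on this core, and nothing available accounts for the difference.

The compounds shown leave open how chloro, an amine or a methoxy group would fare at this position, or whether removing the substituent would restore or reduce growth inhibition. They also leave open whether the same exchange would produce a similar step on the core of compound 1 or compound 3.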